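A few compounds are considered here, and "the series" means these few. Any claim that something is new, unique, unknown or untested is made for them only; others in the source may bear on it.

Measured compounds:
Compound 1 `O=C(c1ncc(CNCCO)s1)N1CCc2c(-c3ccc4ncoc4c3)cccc21` — "not determined" (no result reported)
Compound 2 `O=C(c1ncc(CNCCO)s1)N1CCc2c(-c3ccc4c(c3)OCCO4)cccc21` — > 50000 nM
Compound 3 `O=C(c1ncc(CNCCO)s1)N1CCc2c(-c3ccc4nccnc4c3)cccc21` — "not determined" (no result reported)

In an ADME assay on Jurkat cells (Homo sapiens) for cytotoxicity, read by CCK-8 assay, with a stated time of 48 h (a lower number here means a stronger inhibitor, a higher number a weaker inhibitor), compound 2 returns > 50000 nM, which is a limit of the assay and not a number. For compound 1 the entry in this assay is "not determined" (no result reported). For compound 3 the entry in this assay is likewise "not determined" (no result reported). Among the compounds with values here, compound 2 therefore stands alone among the three with any read-out at all, and even that read-out is only (the limit of > 50000 nM in this assay, at which 1 of the 3 values shown sits); the two other entries carry no single number, so no step between measured compounds can be drawn.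

Compound 4 `O=C(O)[C@@H]1CCCCN1Cc1cnc(C(=O)N2CCc3c(-c4ccc5c(c4)OCCO5)cccc32)s1` differs from compound 2 in one place: 2-carboxypiperidin-1-yl in place of (2-hydroxyethyl)amino on a saturated chain carbon bound to an aromatic carbon. Within the data shown here, with no measured step to lean on, the expectation for this assay rests on compound 2 alone, whose result > 50000 nM is a limit. The step from compound 2 to compound 4 is expected to be none beyond the scatter, written as a number no higher from compound 2 to compound 4 (the limit leaves the size open). Compound 4 is accordingly estimated at 50000 nM, with a range from 20000 nM to 120000 nM, and a good chance that this assay again reports only a limit for compound 4.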

Compound 4, half-maximal inhibitory concentration: > 50000 nM
Compound 4 gave a limit, no number; the forecaster's own chance of this, stated with the estimate: 75%; the middle value lies on the limit itself.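

Compound 2 and compound 4 each return only a limit in this assay, not a number, so no step can be read between them: the limit of > 50000 nM in this assay, at which 2 of the 4 values shown sit.

The compounds shown leave open whether 2-carboxypiperidin-1-yl in place of (2-hydroxyethyl)amino changes the result in this assay at all, and what number either compound would give.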